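This account rests on a few compounds, and the source may have more. Where it says the series, first, only, none or still open, it means among the compounds named here.

Measured compounds:
compound 1, `COc1ccc(-c2cc(C(=O)Nc3ccc(Oc4ccnc5cc(OCCCN6CCCCC6)c(OC)cc45)c(F)c3)c3ccccc3n2)cc1`: 210 nM
compound 2, `COc1cc2c(Oc3ccc(NC(=O)c4cc(-c5cccc(Cl)c5)nc5ccccc45)cc3F)ccnc2cc1OCCCN1CCCCC1`: 11 nM
compound 3, `COc1cc2c(Oc3ccc(NC(=O)c4cc(-c5cccc(Cl)c5)nc5ccc(F)cc45)cc3F)ccnc2cc1OCCCN1CCCC1`: 67 nM

All three were tested in a functional assay on MKN-45 cells (Homo sapiens) for cytotoxicity, read by MTT assay, with a stated time of 72 h; a higher number here means a weaker inhibitor, a lower number a stronger inhibitor. Compound 2 gives 11 nM, the lowest of the three numbers, while compound 1 gives 210 nM and compound 3 gives 67 nM. Compound 1 and compound 2 share one core and differ only in one group: 4-methoxyphenyl in place of 3-chlorophenyl on an aromatic carbon. That single swap produced a 19-fold higher number from compound 2 to compound 1 (1.28 log units; beyond the scatter), so the methoxy-bearing ring made the compound a much weaker inhibitor in this pair.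

Compound 3 has a different core from compound 2; the difference between the two cores is not broken down here. Its number is between those of compound 1 and compound 2.

Compound 4, `COc1ccc(-c2cc(C(=O)Nc3ccc(Oc4ccnc5cc(OCCCN6CCCC6)c(OC)cc45)c(F)c3)c3cc(F)ccc3n2)cc1`, has not yet been tested. It is compound 3 with the very same swap applied: 4-methoxyphenyl in place of 3-chlorophenyl on an aromatic carbon. The place descriptions of this change and of the change from compound 2 to compound 1 agree word for word, so this is the same change on a different core. For the measured compounds named here, with only one earlier example, the size of the effect on the new core is not certain, but the earlier step is the best guide available.

Because a 19-fold higher number from compound 2 to compound 1 (1.28 log units; beyond the scatter), the expected step here is a 15-fold higher number from compound 3 to compound 4 (1.17 log units; beyond the scatter), taken as an estimate of comparable size. In this assay compound 4 is therefore expected to give about 1000 nM, estimated to lie between 300 nM and 3500 nM.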

Compound 4, half-maximal inhibitory concentration: 170 nM
Beside the measured number, compound 4's estimate is 5.9-fold (0.77 log units) above it; measured number below the stated range.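

In this assay, putting 4-methoxyphenyl in place of 3-chlorophenyl again gave a weaker inhibitor, with a 2.5-fold higher number from compound 3 to compound 4 (0.40 log units; beyond the scatter), so the direction of the change held on both cores shown. The size of the step did not carry over, and the two steps clearly differ: the same change on two cores in this assay, a 19-fold higher number (1.28 log units; beyond the scatter) from compound 2 to compound 1 and a 2.5-fold higher number (0.40 log units; beyond the scatter) from compound 3 to compound 4, 7.5-fold (0.88 log units) apart, beyond the scatter of two such steps. These two pairs do not show which difference between the two cores goes with the smaller step, and two examples cannot fix how large the step would be on a third core.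

The swap also changes two things at once, the group on the phenyl ring and its place on that ring, and the compounds shown do not separate the two, so it remains open whether the chlorine, the methoxy group or the shift in position accounts for the steps. As far as these compounds go, it is also open how other groups at this aromatic carbon would behave on these cores, such as an unsubstituted phenyl ring or a phenyl ring carrying a nitrile, and whether they would show the same dependence on the core.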